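The source may report more compounds than this note shows. Statements on the series, on what has been measured and on what is new or still open speak of the compounds shown alone.

In a functional assay on HeLa cells (Homo sapiens) for antiproliferative activity, read by MTT assay, with a stated time of 48 h (a lower number here means a stronger inhibitor, a higher number a weaker inhibitor), two compounds on one shared core have been measured so far. Compound 1 `O=[N+]([O-])c1ccc(-c2nn(-c3ccccc3)cc2C(Nc2nc3ccccc3s2)c2c(O)ccc3ccccc23)cc1` gives 6810 nM and compound 2 `Cc1ccc(-c2nn(-c3ccccc3)cc2C(Nc2nc3ccccc3s2)c2c(O)ccc3ccccc23)cc1` gives 8050 nM with methyl in place of nitro on an aromatic carbon. The measured move is a 1.2-fold higher number from compound 1 to compound 2 (0.07 log units; within the scatter) and lies within the scatter, so compound 2 stands level with compound 1, and neither can be ranked above the other.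

Compound 3 `Oc1ccc2ccccc2c1C(Nc1nc2ccccc2s1)c1cn(-c2ccccc2)nc1-c1ccc(I)cc1` is still unmeasured. It differs from compound 2 at that same aromatic carbon, para to a large group, by iodo in place of methyl on an aromatic carbon and so carries 4-iodophenyl where compound 2 carries 4-methylphenyl. This is iodo in place of methyl on an aromatic carbon. Among the measured compounds shown here, the nitro-to-methyl move is the only measured step that bears on this exchange, and a single small step shows no pattern. No step beyond the scatter is therefore expected in this assay and no direction is favoured. The expected move is a 1.2-fold lower number from compound 2 to compound 3 (0.06 log units; within the scatter) by this estimate. Compound 3 is estimated at 7000 nM within an expected range of 3000 nM to 15000 nM for repeated measurements.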

Compound 3, half-maximal inhibitory concentration: 6590 nM
Estimate against measurement, compound 3: 1.1-fold (0.03 log units) above; the range from low to high includes it.
By their numbers in this assay, from the lowest: compounds 3, 1 and 2 (each within the scatter of the next).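

In this assay, iodo on this aromatic carbon, para to a large group, does not separate from either of the earlier groups: the exchange for methyl gives (a 1.2-fold lower number from compound 2 to compound 3 (0.09 log units; within the scatter)) and the exchange for nitro gives (a 1.0-fold lower number from compound 1 to compound 3 (0.01 log units; within the scatter)). Among the compounds shown here, the earlier compounds offered only one pair, whereas three different groups at this place now stand within the scatter of one another, so the level reading no longer rests on a single step, although it still holds only for nitro, methyl and iodo. Nothing among the available data speaks to why these numbers stand level.

The compounds shown leave open whether an amine, a carboxylic acid or a longer chain such as n-butyl at this same carbon would give a step beyond the scatter in this assay. They also leave open whether changes elsewhere on the shared core, where all three compounds are identical, would be as silent as the exchanges seen at this place.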